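This account rests on a few compounds, and the source may have more. Where it says the series, first, only, none or still open, it means among the compounds named here.

Compound 1 `CCC(=O)N1CCc2nc(C#Cc3ccccc3)sc2C1` in an assay on HEK293 cells for positive allosteric modulation of metabotropic glutamate receptor 5 (Homo sapiens), read by FLIPR, with a stated time of 1 h (a higher number here means that more compound is needed for the effect, a lower number that less compound is needed), gives > 10000 nM; this is a limit of the assay, not a number.
Compound 2 `CC1CC(C(=O)N2CCc3nc(C#Cc4ccccc4)sc3C2)C1` in this assay gives 81 nM.
Compound 3 `N#Cc1cccc(C(=O)N2CCc3nc(C#Cc4ccccc4)sc3C2)c1` in this assay gives 71 nM.

Compound 3 sits at the low end of the two numbers shown, with compound 2 right beside it: the step of a 1.1-fold lower number from compound 2 to compound 3 (0.06 log units; within the scatter) lies within the scatter, so the two cannot be told apart on these data. The next compound, compound 4 `Cc1nc(C(=O)N2CCc3nc(C#Cc4ccccc4)sc3C2)cs1`, differs from compound 3 by 2-methyl-1,3-thiazol-4-yl in place of 3-cyanophenyl on a carbonyl carbon. Among the measured compounds shown here, two measured steps bear on this. Putting a ring group in place of ethyl on the carbonyl carbon gave large steps, an at least 120-fold lower number from compound 1 to compound 2 (2.09 log units; beyond the scatter) and an at least 140-fold lower number from compound 1 to compound 3 (2.14 log units; beyond the scatter), whereas exchanging one ring group for another, a 1.1-fold lower number from compound 2 to compound 3 (0.06 log units; within the scatter), gave nothing beyond the scatter. The exchange to the 2-methyl-1,3-thiazol-4-yl group is another ring-for-ring swap, so the expected step in this assay is a 1.5-fold higher number from compound 3 to compound 4 (0.19 log units; within the scatter), which stays within the scatter. Compound 4 is estimated at 110 nM, with a range from 35 nM to 400 nM.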

Compound 4, half-maximal effective concentration: 220 nM
Beside the measured number, compound 4's estimate is 2.0-fold (0.30 log units) below it, within the range that was stated.
By their numbers in this assay, from the lowest: compounds 3 and 2 (each within the scatter of the next); then compound 4. At a limit, above all of these: compound 1.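

In this assay, a ring-for-ring exchange on the carbonyl carbon can now move the number beyond the scatter: a 3.1-fold higher number from compound 3 to compound 4 (0.49 log units; beyond the scatter), and a 2.7-fold higher number from compound 2 to compound 4 (0.43 log units; beyond the scatter), so the choice of ring group matters here in a way that compound 2 and compound 3 alone could not show. The 2-methyl-1,3-thiazol-4-yl group still stands far from ethyl, with an at least 45-fold lower number from compound 1 to compound 4 (1.65 log units; beyond the scatter). The value of compound 1 is a limit, so this last step is only a bound: the limit of > 10000 nM in this assay, at which 1 of the 4 values shown sits.

Compound 4 changes the ring size, the hetero atoms and the substituent all at once, and these compounds do not separate those changes. Also open, on these data alone, is how a plain phenyl, a longer alkyl chain or a group carrying an amine on the carbonyl carbon would behave in this assay.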